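The source may report more compounds than this note shows. Statements on the series, on what has been measured and on what is new or still open speak of the compounds shown alone.

The study covers three measured compounds built on a shared core, with one more awaiting measurement. Compound 1 `C/C(=C\c1ccc(NC(=O)Nc2ccc(Cl)c(C(F)(F)F)c2)cc1)C(=O)NC(C)c1ccccc1` reaches only the limit of the assay in a functional assay on KETR3 cells (Homo sapiens) for inhibition, read by MTT assay, with a stated time of 120 h (a higher number here means a weaker inhibitor, a lower number a stronger inhibitor), reported as > 50000 nM. Compound 3 `CC1CN(C(=O)CCc2ccc(NC(=O)Nc3ccc(Cl)c(C(F)(F)F)c3)cc2)CC(C)O1` likewise gives in this assay a limit, > 50000 nM. Going by the values given here, compound 2 `CC1CN(C(=O)c2ccc(-c3ccc(NC(=O)Nc4ccc(Cl)c(C(F)(F)F)c4)cc3)cc2)CC(C)O1` is the one compound that returns a number in this assay, 41900 nM, and so stands alone among the three as the single measured value, while the limit of > 50000 nM in this assay, at which 2 of the 3 values shown sit, marks where the other two sit. Among the compounds with values here, no step between measured compounds differing in a single place can be drawn from these three.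

Compound 4 `CC1CN(C(=O)c2ccc(-c3ccc(NC(=O)Nc4cc(C(F)(F)F)ccc4Cl)cc3)cc2)CC(C)O1` has not yet been measured. Its difference from compound 2 is 2-chloro-5-(trifluoromethyl)phenyl in place of 4-chloro-3-(trifluoromethyl)phenyl on an amide-type nitrogen. With compound 2 giving 41900 nM, the step is expected to stay within the scatter, a 1.2-fold higher number from compound 2 to compound 4 (0.08 log units; within the scatter), with no clear direction. Compound 4 is therefore estimated at 50000 nM, in a range from 20000 nM to 150000 nM, with a real chance that only a limit is reported.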

Compound 4, half-maximal inhibitory concentration: > 50000 nM
Compound 4: only a limit was reported; the forecaster's own chance of this, stated with the estimate: 55%; the middle value lies on the limit itself.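

Going by these compounds alone, with the same atoms joined differently, 2-chloro-5-(trifluoromethyl)phenyl in place of 4-chloro-3-(trifluoromethyl)phenyl on the amide-type nitrogen gives the first step that can be read in this assay, and that step has only a floor: an at least 1.1-fold higher number from compound 2 to compound 4 (0.07 log units; that floor lies within the scatter). In this assay compound 4 gives only a limit, > 50000 nM. Within the data shown here, compound 2 thus remains the only compound with a number, and the others share one limit: the limit of > 50000 nM in this assay, at which 3 of the 4 values shown sit.

The compounds shown leave open how far the step reaches beyond its floor, and so whether this change at the amide-type nitrogen matters at all in this assay. They also leave open whether another group at this place, such as an unsubstituted phenyl or a pyridine ring, would give a number clearly lower than that of compound 2.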